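From 3-bromophenyl to 4-chlorophenyl on the shared core

The source may hold more compounds than are shown below. What is called first, only, known or untested is meant among the compounds shown, and "the series" means these compounds.

Compound 2 (`O=C(/C=C/c1cccc(Br)c1)c1cccc(-c2cccc(F)c2)c1`) gives 6980 nM in a functional assay on HepG2 cells (Homo sapiens) for cytotoxicity, read by sulforhodamine B assay, with a stated time of 48 h (a higher number here means a weaker inhibitor, a lower number a stronger inhibitor), and stands level with compound 1 (`COc1cc(/C=C/C(=O)c2cccc(-c3cccc(F)c3)c2)ccc1O`) at 6830 nM within the scatter. Compound 3 (`COc1ccc(/C=C/C(=O)c2cccc(-c3cccc(F)c3)c2)cc1OC`) at 1170 nM lies beyond the scatter of both, with a lower number. Compound 4 (`O=C(/C=C/c1ccc(Cl)cc1)c1cccc(-c2cccc(F)c2)c1`) differs from compound 2 in one place: 4-chlorophenyl in place of 3-bromophenyl on a double-bonded chain carbon bound to a double-bonded chain carbon is the whole change. For the measured compounds named here, no measured step makes this exchange. The only one, a 5.8-fold lower number from compound 1 to compound 3 (0.77 log units; beyond the scatter) for methyl in place of hydrogen on an oxygen on an aromatic ring, is a different change and offers no size to carry over. No step beyond the scatter is therefore expected, and the estimated step is a 1.3-fold lower number from compound 2 to compound 4 (0.10 log units; within the scatter) at most in size. In this assay the expected value for compound 4 is 5500 nM (estimated range 2000 nM to 15000 nM).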

Compound 4, half-maximal inhibitory concentration: 10400 nM
Estimate against measurement, compound 4: 1.9-fold (0.28 log units) below; the measured number falls inside the stated range.
By their numbers in this assay, from the lowest: compound 3; then compounds 1, 2 and 4 (each within the scatter of the next).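

In this assay, 4-chlorophenyl in place of 3-bromophenyl on a double-bonded chain carbon bound to a double-bonded chain carbon gives a 1.5-fold higher number from compound 2 to compound 4 (0.17 log units; within the scatter) and so leaves the reading within the scatter. For the compounds shown here, this is the first measured change at this position, and the earlier step concerned only methyl in place of hydrogen on an oxygen on an aromatic ring. Here, moving from one halogen-bearing phenyl group to another does not shift the number measurably. Going by these compounds, what an amine or a carboxylic acid on the phenyl ring at this position would give remains open. No available measurement bears on the reason for this result.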